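The compounds below may be only part of what the source reports. "The series", "measured", "known", "first", "only" and "open" are said of these compounds alone.

Compound 2 `COC(=O)/C=C/c1cccc(N(Cc2ccc(/C=C/C(=O)OC(C)(C)C)cc2)C(=O)NC(C)C)c1` is the starting point here. In an assay on isolated protein with Bile acid receptor (Homo sapiens) as the target (a lower number here means that less compound is needed, a higher number that more compound is needed for the effect), compound 2 gives 212 nM. For the measured compounds named here, only one other compound has been measured, compound 1 `COC(=O)/C=C/c1cccc(N(Cc2ccc(/C=C/C(=O)OC(C)(C)C)cc2)C(=O)c2ccccc2)c1`, which in this assay gives 236 nM; the step of a 1.1-fold lower number from compound 1 to compound 2 (0.05 log units; within the scatter) is too small to separate the two, so compound 2 stands at one of two numbers that are, for practical purposes, the same.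

Compound 3 `COC(=O)/C=C/c1cccc(N(Cc2ccc(/C=C/C(=O)OC(C)(C)C)cc2)C(=O)NCc2ccccc2)c1` has not yet been measured. It differs from compound 2 in one place: benzyl in place of isopropyl on an amide-type nitrogen. Going by the values given here, the only measured step that touches the same end of the molecule is the exchange at the carbonyl carbon, a 1.1-fold lower number from compound 1 to compound 2 (0.05 log units; within the scatter), which stayed within the scatter. Among the compounds with values here, no measured step tests a change on the amide-type nitrogen itself. The expectation for compound 3 is therefore a step of a 1.0-fold higher number from compound 2 to compound 3 (0.02 log units; within the scatter), nothing beyond the scatter, so compound 3 is estimated at 220 nM, with a range from 90 nM to 550 nM.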

Compound 3, half-maximal effective concentration: > 1000 nM
Compound 3: a limit, no number (the forecaster's own chance of this, stated with the estimate: 3%); middle value at least 4.5-fold (0.65 log units) from the limit.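

Unlike the exchange on the carbonyl carbon, which gave only a 1.1-fold lower number from compound 1 to compound 2 (0.05 log units; within the scatter), the amide-type nitrogen is sensitive to what it carries: benzyl in place of isopropyl gives an at least 4.7-fold higher number from compound 2 to compound 3 (0.67 log units; beyond the scatter). An aromatic ring as such does not explain this, since phenyl on the carbonyl carbon and isopropylamino there read alike, while benzylamino in place of that phenyl gives an at least 4.2-fold higher number from compound 1 to compound 3 (0.62 log units; beyond the scatter). The result for the benzyl compound is a limit and not a number, so both steps give only a minimum size: the limit of > 1000 nM in this assay, at which 1 of the 3 values shown sits.

The compounds shown do not tell whether the ring of benzyl or simply its added carbons matter. A cyclohexylmethyl group or a longer chain such as n-butyl on the same nitrogen would separate these two readings.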